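Changing the Sulfonamide Group: Compound 3 to Compound 4

The source may report more compounds than this note shows. Statements on the series, on what has been measured and on what is new or still open speak of the compounds shown alone.

Compound 1 `CCCS(=O)(=O)c1cccc(C#Cc2cc(Cl)ccc2OCC(=O)O)c1`: < 10 mL.min-1.g-1 (a limit of the assay, not a number)
Compound 2 `COCCN(C)S(=O)(=O)c1ccc(C)c(C#Cc2cc(Cl)ccc2OCC(=O)O)c1`: 49 mL.min-1.g-1
Compound 3 `Cc1ccc(S(=O)(=O)N(C)C(C)C)cc1C#Cc1cc(Cl)ccc1OCC(=O)O`: 64 mL.min-1.g-1

These results come from an in vitro ADME assay on microsomes from liver (Rattus norvegicus) for metabolic stability, read by LC-MS, tested at 1 uM; on this read-out higher numbers stand for fast clearance and lower numbers for slow clearance. Compound 1 gives < 10 mL.min-1.g-1, which is a limit and not a measured number. That leaves two true numbers to compare. Compound 2 gives 49 mL.min-1.g-1 and compound 3 gives 64 mL.min-1.g-1, and these two lie within the scatter of each other.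

Compound 4 `COCCNS(=O)(=O)c1ccc(C)c(C#Cc2cc(Cl)ccc2OCC(=O)O)c1` has not yet been measured. It differs from compound 3 by having (2-methoxyethyl)amino in place of isopropyl(methyl)amino on a sulfonyl sulfur. Among the compounds with values here, one measured step bears on this change: a 1.3-fold higher number from compound 2 to compound 3 (0.12 log units; within the scatter). It swaps isopropyl for 2-methoxyethyl on a sulfonamide nitrogen, and its size lies within the scatter. Within the data shown here, no measured step covers the hydrogen-bond donor that enters with compound 4.

The expected result is therefore a small move towards a lower number, not clearly beyond the scatter of this assay. The estimated change is a 1.6-fold lower number from compound 3 to compound 4 (0.20 log units; within the scatter). For compound 4 the estimated value is 40 mL.min-1.g-1, with an expected range of 15 mL.min-1.g-1 to 80 mL.min-1.g-1.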

Compound 4, intrinsic clearance in microsomes: < 10 mL.min-1.g-1
Compound 4 ended at the assay's limit (the forecaster's own chance of this, stated with the estimate: 10%); middle value at least 4.0-fold (0.60 log units) away from the limit.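

In this assay, within the data shown here, the earlier compounds showed only that exchanging one group on the sulfonamide nitrogen for another left the number within the scatter, with the step being a 1.3-fold higher number from compound 2 to compound 3 (0.12 log units; within the scatter). Removing the methyl from that nitrogen and leaving hydrogen there is a single change of a different kind, and it gives an at least 4.9-fold lower number from compound 2 to compound 4 (0.69 log units; beyond the scatter). The full exchange of isopropyl(methyl)amino for (2-methoxyethyl)amino on the sulfonyl sulfur gives an at least 6.4-fold lower number from compound 3 to compound 4 (0.80 log units; beyond the scatter), and for compound 4 both steps are minimum sizes, since its reading is a limit and not a number: the limit of < 10 mL.min-1.g-1 in this assay, at which 2 of the 4 values shown sit.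

The compounds shown leave open whether the hydrogen on the nitrogen would give a similar drop with isopropyl in place of 2-methoxyethyl, or whether an ethyl group on that nitrogen would behave like the methyl or like the hydrogen. They also leave open whether a longer chain, or a chain ending in an amine instead of the methoxy group, would keep the clearance reading as low as that of compound 4.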